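The compounds below may be only part of what the source reports. "The series", "measured", "known", "first", "only" and "open" are said of these compounds alone.

Compound 1 `COc1cc(C(=O)c2sc(Nc3ccccc3)nc2N)cc(OC)c1OC`: 14 nM
Compound 2 `COc1ccc(Nc2nc(N)c(C(=O)c3ccccc3)s2)cc1`: 230 nM
Compound 3 `COc1cc(C(=O)c2sc(Nc3ccc(F)cc3)nc2N)cc(OC)c1OC`: 440 nM

All three values come from a functional assay on HeLa cells (Homo sapiens) for antiproliferative activity, read by cell counting, with a stated time of 2 days; on this read-out higher numbers stand for weaker inhibition and lower numbers for stronger inhibition. Compound 3 lies within the scatter of compound 2 and well above compound 1. The next compound is compound 4 `COc1cc(C(=O)c2sc(Nc3ccc(C)cc3)nc2N)cc(OC)c1OC`, and the change is methyl in place of fluoro on an aromatic carbon, para to a large group. Among the compounds with values here, one measured step bears on this carbon: a 31-fold higher number from compound 1 to compound 3 (1.50 log units; beyond the scatter), a large step with fluoro in place of hydrogen. Within the data shown here, no methyl compound has been measured, so the size of the step is uncertain. A moderate step to a lower number is expected in this assay. The expected step is a 4.0-fold lower number from compound 3 to compound 4 (0.60 log units; beyond the scatter). For compound 4 the estimate is 110 nM, with an expected range of 20 nM to 550 nM.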

Compound 4, half-maximal inhibitory concentration: 86 nM
Compound 4: the middle estimate sits 1.3-fold (0.11 log units) above what was measured, within the range that was stated.
By their numbers in this assay, from the lowest: compound 1; then compound 4; then compounds 2 and 3 (each within the scatter of the next).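

In this assay this carbon tolerates methyl better than fluoro, with a 5.1-fold lower number from compound 3 to compound 4 (0.71 log units; beyond the scatter) on going from 4-fluorophenyl to 4-methylphenyl. Hydrogen still gives the lowest number of the three, with a 6.1-fold higher number from compound 1 to compound 4 (0.79 log units; beyond the scatter) on adding the methyl, so both groups raise the number here, and fluoro raises it further. No evidence on the reason for this order is available.

Open, as far as these compounds go, is whether a longer chain such as ethyl would raise the number further than methyl does. Also open, from the compounds shown here alone, is where chloro or an amine on this carbon would fall relative to hydrogen.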